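The compounds below may be only part of what the source reports. "The series", "measured", "known", "first", "only" and "open" are said of these compounds alone.

Measured compounds:
- Compound 1 `C=CCOc1ccc(F)cc1C(=O)c1cccnc1`: > 100000 nM
- Compound 2 `C=CCOc1c(Cl)cc(Cl)cc1C(=O)c1cccnc1`: 96000 nM
- Compound 3 `O=C(c1cccnc1)c1cc(F)ccc1O`: 11800 nM

In a functional assay on PC-3 cells (Homo sapiens) for cytotoxicity, read by sulforhodamine B assay, with a stated time of 48 h (on this read-out higher numbers stand for weaker inhibition and lower numbers for stronger inhibition), compound 1 gives > 100000 nM, which is a limit of the assay rather than a number. Compound 2 gives 96000 nM and compound 3 gives 11800 nM. Among the compounds with values here, the one step that joins two measured compounds in one place is an at least 8.4-fold lower number from compound 1 to compound 3 (0.92 log units; beyond the scatter), and it concerns the allyl ether, not the fluoro. Compound 1 itself sits at the limit of > 100000 nM in this assay, at which 1 of the 3 values shown sits.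

Compound 4 `C=CCOc1ccc(C)cc1C(=O)c1cccnc1` keeps the allyl ether of compound 1 and changes a different position: methyl in place of fluoro on an aromatic carbon. Within the data shown here, no measured step touches this position, so the expectation rests on compound 1 and compound 2, both allyl ethers with halogen on the same ring and both weak in this assay. The change is therefore expected to bring no step beyond the scatter, and compound 4 is expected to stay weak, with a fair chance of another limit. The estimated step is a number no higher from compound 1 to compound 4 (the limit leaves the size open), giving compound 4 an expected value of 100000 nM, within 40000 nM to 300000 nM.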

Compound 4, half-maximal inhibitory concentration: 98000 nM
The estimate for compound 4 lay 1.0-fold (0.01 log units) above the measured number; the measured number falls inside the stated range.
By their numbers in this assay, from the lowest: compound 3; then compounds 2 and 4 (each within the scatter of the next). At a limit, above all of these: compound 1.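

In this assay, the change to methyl in place of fluoro on this aromatic carbon, para to an allyloxy group, can be read only as an at least 1.0-fold lower number from compound 1 to compound 4 (0.00 log units; that floor lies within the scatter). This is the only step shown at this position, and with the allyl ether kept, compound 4 gives 98000 nM, so methyl brings no step here that can be read as beyond the scatter. How large the step truly is stays open because compound 1 stands at a limit of the assay rather than at a number: the limit of > 100000 nM in this assay, at which 1 of the 4 values shown sits.

The compounds shown do not tell how an amine, a carboxylic acid or a longer chain would fare at this position. They also leave open whether methyl and fluoro would differ once the allyl ether gives way to the free hydroxyl of compound 3.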